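The source may report more compounds than this note shows. Statements on the series, on what has been measured and on what is new or still open speak of the compounds shown alone.

Compound 2, `Cc1cc(=O)n(-c2ccccc2C(F)(F)F)nc1C(=O)Nc1ccc(Oc2ncnc3ccsc23)c(F)c1`, is the lower of the two numbers recorded in a functional assay on HepG2 cells (Homo sapiens) for cytotoxicity, read by MTT assay, with a stated time of 72 h; on this read-out higher numbers stand for weaker inhibition and lower numbers for stronger inhibition: in this assay compound 2 gives 9380 nM, while compound 1, `Cc1cc(=O)n(-c2ccccc2OC(F)(F)F)nc1C(=O)Nc1ccc(Oc2ncnc3ccsc23)cc1`, gives 25000 nM, a gap that lies beyond the scatter. Compound 3, `Cc1cc(=O)n(-c2ccccc2OC(F)(F)F)nc1C(=O)Nc1ccc(Oc2ncnc3ccsc23)c(F)c1`, has not yet been measured. Relative to compound 2 it carries trifluoromethoxy in place of trifluoromethyl on an aromatic carbon, placed on an aromatic carbon of a six-membered aromatic ring of carbon only, ortho to a large group. Going by the values given here, no measured pair shows this exchange on its own, so the step from compound 2 to compound 3 in this assay has no direct precedent. Compound 1 already holds the trifluoromethoxy group but lacks the ring fluorine of compound 2, and its number is the weaker of the two. A modest weakening is therefore expected for compound 3, of the size a 1.6-fold higher number from compound 2 to compound 3 (0.20 log units; within the scatter). For compound 3 the value is estimated at 15000 nM, within the range 6000 nM to 40000 nM.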

Compound 3, half-maximal inhibitory concentration: 15700 nM
The estimate for compound 3 lay 1.0-fold (0.02 log units) below the measured number; the measured number falls inside the stated range.
By their numbers in this assay, from the lowest: compounds 2, 3 and 1 (each within the scatter of the next, the first and the last beyond it).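

In this assay, compound 3 separates two single exchanges that compound 1 and compound 2, which differ in two places, could not show apart. Trifluoromethoxy in place of trifluoromethyl, on an aromatic carbon ortho to a large group, gives a 1.7-fold higher number from compound 2 to compound 3 (0.22 log units; within the scatter) and fluoro in place of hydrogen on an aromatic carbon gives a 1.6-fold lower number from compound 1 to compound 3 (0.20 log units; within the scatter) and, as both steps lie within the scatter, neither exchange alone has a resolved effect on this read-out. Nothing available explains these steps.

The compounds shown leave open whether a different group in place of trifluoromethoxy, such as methoxy, chloro or a nitrile, would shift the number beyond the scatter. They also leave open whether chloro or an amine in place of the ring fluoro would do so.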